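This account rests on a few compounds, and the source may have more. Where it says the series, first, only, none or still open, it means among the compounds named here.

Measured so far:
Compound 1 `CC(=O)Nc1cccc(-c2ccc(C(=O)N(Cc3cccc(OCCCCCC(=O)O)c3)C(C)C)cc2)c1` in an ADME assay on BJ cells (Homo sapiens) for cytotoxicity, read by CellTiter-Glo and resazurin assay, with a stated time of 72 h; on this read-out higher numbers stand for an effect only at larger amounts of compound and lower numbers for an effect already at smaller amounts: > 26000 nM, a limit of the assay.
Compound 2 `CC(C)N(Cc1cccc(OCCCCCC(=O)O)c1)C(=O)c1ccc(-c2ccc3[nH]ccc3c2)cc1` in this assay : > 26000 nM, a limit of the assay.

For the measured compounds named here, compound 2 thus stands only at a limit, and the one further value shown is a limit as well; both sit at the limit of > 26000 nM in this assay, at which 2 of the 2 values shown sit. The step that the two limits leave unreadable from compound 1 to compound 2 is therefore not readable in size or direction. Compound 3 `CCOc1cccc(-c2ccc(C(=O)N(Cc3cccc(OCCCCCC(=O)O)c3)C(C)C)cc2)c1` carries 3-ethoxyphenyl in place of 1H-indol-5-yl on an aromatic carbon. No readable step bears on this change, so no step beyond the scatter is expected, a step that the limit leaves unreadable from compound 2 to compound 3, and most likely compound 3 again reaches only the limit. Compound 3 is estimated at 40000 nM, range 20000 nM to 100000 nM.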

Compound 3, half-maximal effective concentration: > 20800 nM
Compound 3 ended at the assay's limit (the forecaster's own chance of this, stated with the estimate: 80%); the middle value is on the limit's open side.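

For the compounds shown here, compound 1, compound 2 and compound 3 all stand at limits in this assay; no step among them can be read. The compounds shown leave open at what concentration any of the three reaches its half-maximal effect.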